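The source may hold more compounds than are shown below. What is called first, only, known or untested is meant among the compounds shown, and "the series" means these compounds.

Compound 1 `CCCc1nc(C)c2c(C)nn(CC(=O)O)c(=O)n12`: > 48000 nM
Compound 2 `COCc1nc(C)c2cnnc(S)n12`: > 48000 nM

In a functional assay for inhibition, with Homo sapiens as the target (on this read-out lower numbers stand for stronger inhibition and higher numbers for weaker inhibition), compound 1 gives > 48000 nM, which is a limit of the assay rather than a number. Compound 2 likewise returns only a limit, > 48000 nM. For the measured compounds named here, both results sit at the limit of > 48000 nM in this assay, at which 2 of the 2 values shown sit, so compound 1 stands at the edge of what this assay reports, and no measured step links it to any other compound. Compound 3 `CCCc1nc(C)c2c(C)nn(Cc3ccccc3)c(=O)n12` differs from compound 1 by phenyl in place of carboxy on a saturated chain carbon bound to an aromatic nitrogen. Without a measured step to lean on, only a modest shift is expected, in either direction: the expected step is an at least 1.6-fold lower number from compound 1 to compound 3 (0.20 log units; that floor lies within the scatter). Compound 3 is therefore estimated at 30000 nM, between 5000 nM and 100000 nM.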

Compound 3, half-maximal inhibitory concentration: > 48000 nM
Compound 3: no number, only a limit; the forecaster's own chance of this, stated with the estimate: 60%; middle value at least 1.6-fold (0.20 log units) away from the limit.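

Compound 1 and compound 3 each give only a limit in this assay, not a number, so the step between them cannot be read: the limit of > 48000 nM in this assay, at which 3 of the 3 values shown sit.

The compounds shown leave open what change to the shared core, if any, would bring a readable number in this assay.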